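Swapping Dimethylamino for Chloro on a Shared Core

The source may hold more compounds than are shown below. What is called first, only, known or untested is meant among the compounds shown, and "the series" means these compounds.

Going by the values given here, in this series the shared core is kept, and only one group on the outer aromatic ring changes. Among the compounds with values here, compound 2 `Cc1ccc(CN2C(=O)S/C(=C\c3ccc(N(C)C)cc3)C2=O)cc1` gives 44.1% in a functional assay on the whole organism (plasma) with Mus musculus as the target, with a stated time of 15 days, at a dose of 30 mg/kg by the oral route (on this read-out higher numbers stand for a stronger effect at the one dose given and lower numbers for a weaker effect), the higher of the two numbers measured so far. Compound 1 `Cc1ccc(CN2C(=O)S/C(=C\c3ccc([N+](=O)[O-])cc3)C2=O)cc1` gives 7.1% in this assay. Within the data shown here, the single measured step between them is a number 37 percentage points higher from compound 1 to compound 2 (beyond the scatter), showing that the group at this position can move the read-out strongly. Compound 3 `Cc1ccc(CN2C(=O)S/C(=C\c3ccc(Cl)cc3)C2=O)cc1` differs from compound 2 by chloro in place of dimethylamino on an aromatic carbon. Among the measured compounds shown here, no measured step involves chloro, so the nitro-to-dimethylamino step is the only guide. As chloro is neither of the groups measured, compound 3 is expected to fall between the two values seen. The step is expected to be a number 24.1 percentage points lower from compound 2 to compound 3 (beyond the scatter). The value for compound 3 in this assay is estimated at 20%, with a range from 5% to 40%.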

Compound 3, a percentage reported as activity, at one dose (the size of the read-out at that dose, not a potency): 48%
Compound 3: the middle estimate sits 28 percentage points below what was measured, and the stated range ends below it.
By their numbers in this assay, from the lowest: compound 1; then compounds 2 and 3 (each within the scatter of the next).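

Chloro in place of dimethylamino gives a number 3.9 percentage points higher from compound 2 to compound 3 (within the scatter) in this assay so these two groups cannot be told apart on this read-out at this place on the ring, even though one has a single heavy atom and the other has three. Chloro in place of nitro gives a number 40.9 percentage points higher from compound 1 to compound 3 (beyond the scatter) and this second large step shows that, among these three compounds, nitro alone stands apart, while two quite different groups give numbers within the scatter of each other. Nothing measured here explains why these groups compare as they do.

The compounds shown leave open whether methoxy, a carboxylic acid or a longer amine at this place would stay with compound 2 and compound 3 or fall toward compound 1. They also leave open whether this order of groups would hold with a change elsewhere on the shared core.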